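Side-chain variation on the shared core: cytotoxicity notes

The compounds below may be only part of what the source reports. "The series", "measured", "known", "first", "only" and "open" are said of these compounds alone.

Compound 3 `Cc1ccc(S(=O)(=O)N2Cc3ccccc3OC[C@@H]2C(C)C)cc1` carries an isopropyl on a saturated ring carbon of the shared core. In a functional assay on MDA-MB-231 cells (Homo sapiens) for cytotoxicity, read by MTT assay, with a stated time of 18 h (on this read-out lower numbers stand for stronger inhibition and higher numbers for weaker inhibition), compound 3 gives > 50000 nM, which is a limit of the assay and not a number. Compound 1 `Cc1ccc(S(=O)(=O)N2Cc3ccccc3OC[C@@H]2C)cc1` gives > 50000 nM in this assay, again a limit. Compound 2 `Cc1ccc(S(=O)(=O)N2Cc3ccccc3OC[C@@H]2CC(C)C)cc1` gives > 50000 nM in this assay, also a limit. Because all three sit at the limit of > 50000 nM in this assay, at which 3 of the 3 values shown sit, the steps a step that the two limits leave unreadable from compound 1 to compound 3 and a step that the two limits leave unreadable from compound 2 to compound 3 cannot be sized, nor can a step that the two limits leave unreadable from compound 1 to compound 2. Compound 4 `CCC(C)[C@H]1COc2ccccc2CN1S(=O)(=O)c1ccc(C)cc1` differs from compound 3 by methyl in place of hydrogen on a saturated chain carbon, two bonds along the chain from a saturated ring carbon. No readable step bears on this change, so the step that the limit leaves unreadable from compound 3 to compound 4 is expected to be none beyond the scatter. Compound 4 is therefore estimated at 60000 nM, within 20000 nM to 200000 nM, most probably reported as a limit once more.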

Compound 4, half-maximal inhibitory concentration: > 50000 nM
Compound 4 ended at the assay's limit (the forecaster's own chance of this, stated with the estimate: 85%); the middle value is on the limit's open side.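

No new step can be read from compound 4 to compound 1, compound 2 or compound 3, because all four stop at one assay limit: the limit of > 50000 nM in this assay, at which 4 of the 4 values shown sit.

The compounds shown leave open whether any side chain on the shared core gives a measurable value in this assay.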